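This account rests on a few compounds, and the source may have more. Where it says the series, first, only, none or still open, it means among the compounds named here.

Measured so far in a functional assay on BHK cells for positive allosteric modulation of metabotropic glutamate receptor 5 (Homo sapiens), read by FLIPR and calcium flux; a higher number here means that more compound is needed for the effect, a lower number that less compound is needed:
compound 1 `O=C(NC1CCCCC1)c1ccc(C#Cc2ccccc2)nc1`: 240 nM
compound 2 `CC1CCN(C(=O)c2ccc(C#Cc3ccccc3)nc2)CC1`: 130 nM
compound 3 `CN1CCN(C(=O)c2ccc(C#Cc3ccccc3)nc2)CC1`: 1600 nM

Compound 1 stands second highest of the three numbers; compound 2 sits nearest, compound 3 furthest. Compound 4 `O=C(c1ccc(C#Cc2ccccc2)nc1)N1CCOCC1` differs from compound 1 by morpholin-4-yl in place of cyclohexylamino on a carbonyl carbon. Within the data shown here, two measured steps bear on this change at the same carbonyl carbon: a 1.8-fold lower number from compound 1 to compound 2 (0.27 log units; within the scatter) and a 6.7-fold higher number from compound 1 to compound 3 (0.82 log units; beyond the scatter). The incoming group is a ring amine, as in compound 2, but carries a hetero atom within the ring, as in compound 3, whose step went beyond the scatter. A step upward of moderate size is therefore expected, a 2.5-fold higher number from compound 1 to compound 4 (0.40 log units; beyond the scatter), though the evidence is thin and the range is wide. Compound 4 is estimated at 600 nM in this assay, between 200 nM and 2000 nM.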

Compound 4, half-maximal effective concentration: 990 nM
The estimate for compound 4 lay 1.7-fold (0.22 log units) below the measured number; measured number inside the range.
By their numbers in this assay, from the lowest: compounds 2 and 1 (each within the scatter of the next); then compounds 4 and 3 (each within the scatter of the next).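

In this assay morpholin-4-yl on the carbonyl carbon gives a 4.1-fold higher number from compound 1 to compound 4 (0.62 log units; beyond the scatter) and a 7.6-fold higher number from compound 2 to compound 4 (0.88 log units; beyond the scatter) but only a 1.6-fold lower number from compound 3 to compound 4 (0.21 log units; within the scatter) in this short series. The two rings with 2 hetero atoms are thus not told apart here, and both lie beyond the scatter from compound 1 and compound 2. No measurement at hand accounts for this.

Open, going by these compounds, is whether an open-chain amine such as diethylamino, or a 4-hydroxypiperidin-1-yl group, on the same carbonyl carbon would read with compound 2 or with compound 4.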